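The compounds below may be only part of what the source reports. "The series", "measured", "known", "first", "only" and "open" are said of these compounds alone.

Working notes on the series. For the measured compounds named here, in a functional assay on SMMC-7721 cells (Homo sapiens) for cytotoxicity, read by MTT assay, with a stated time of 24 h (a higher number here means a weaker inhibitor, a lower number a stronger inhibitor), compound 2 `O=C1/C(=C/c2cccnc2)CN(S(=O)(=O)c2ccc(Br)cc2)C/C1=C\c1ccccc1F` gives 9100 nM, the only true number so far. Compound 1 `O=C1/C(=C/c2cccnc2)CN(S(=O)(=O)c2ccc([N+](=O)[O-])cc2)C/C1=C\c1ccccc1F` reads > 20000 nM, which is a limit of the assay and not a number.

Compound 3 `N#Cc1ccc(S(=O)(=O)N2C/C(=C\c3cccnc3)C(=O)/C(=C/c3ccccc3F)C2)cc1` carries cyano in place of bromo on an aromatic carbon, with cyano in place of bromo on an aromatic carbon, para to a large group. Going by the values given here, the only measured step, an at least 2.1-fold lower number from compound 1 to compound 2 (0.34 log units; beyond the scatter), is bromo in place of nitro on that same aromatic carbon. Among the compounds with values here, it shows that the read-out can move with this group, but no measured compound carries cyano, so its size transfers only loosely.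

A small move toward a weaker reading in this assay is expected, a 1.4-fold higher number from compound 2 to compound 3 (0.15 log units; within the scatter), and it may not clear the scatter. For compound 3 the estimated value is 13000 nM, with an expected range of 5500 nM to 28000 nM.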

Compound 3, half-maximal inhibitory concentration: 15400 nM
Estimate against measurement, compound 3: 1.2-fold (0.07 log units) below, and the stated range covers the measured number.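

In this assay, this aromatic carbon now has a second measured replacement for nitro, and cyano and bromo are not separated here (a 1.7-fold higher number from compound 2 to compound 3 (0.23 log units; within the scatter)). The earlier step showed a shift beyond the scatter on going from nitro to bromo, whereas the floor for going from nitro to cyano does not clear it (an at least 1.2-fold lower number from compound 1 to compound 3 (0.11 log units; that floor lies within the scatter)), so cyano and nitro are not separated on the values shown. Compound 1 remains a limit of the assay and not a number: the limit of > 20000 nM in this assay, at which 1 of the 3 values shown sits.

Going by these compounds, whether an amino group or a carboxylic acid on this aromatic carbon would give a reading clearly apart from compound 2 stays open. The compounds shown differ only at this one place, so they say nothing about changes elsewhere on the shared core.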